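A sulfonyl precedent for an acetyl on the pyrazole nitrogen

This account rests on a few compounds, and the source may have more. Where it says the series, first, only, none or still open, it means among the compounds named here.

Of the compounds shown here, three sharing one core have been measured in a functional assay on MV4-11 cells (Homo sapiens) for antiproliferative activity, with a stated time of 6 days, tested at 6.25 uM; on this read-out lower numbers stand for a weaker effect and higher numbers for a stronger effect at the one concentration tested. Compound 1 `CNC(=O)N1CCCc2ccc(NC(=O)c3ccc(-c4cc[nH]n4)cc3)cc21` gives 99.1%, the highest of the three numbers. Compound 2 `CNC(=O)N1CCCc2ccc(NC(=O)c3cccc(-c4cnn(C)c4)c3)cc21` gives 93.5%, within the scatter of compound 1, so the two cannot be ordered. Compound 3 `CNC(=O)N1CCCc2ccc(NC(=O)c3cccc(-c4ccn(S(C)(=O)=O)n4)c3)cc21` gives 37%, well beyond the scatter below both. Among the measured compounds shown here, the one measured step within this set, a number 56.5 percentage points lower from compound 2 to compound 3 (beyond the scatter), is large and downward, though it combines a change of the group on the ring nitrogen with a change of attachment point.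

Compound 4 `CNC(=O)N1CCCc2ccc(NC(=O)c3ccc(-c4ccn(C(C)=O)n4)cc3)cc21` differs from compound 1 in one place: acetyl in place of hydrogen on an aromatic nitrogen. For the measured compounds named here, no measured pair shows exactly hydrogen against acetyl on that nitrogen; the step from compound 2 to compound 3, which also replaces a small group on the ring nitrogen with a larger one bearing a carbonyl-like acceptor, is the nearest guide and points downward. A drop beyond the scatter is therefore expected, though smaller than that step, since the attachment point is unchanged here. Compound 4 is expected to give 60%, within 20% to 95%, corresponding to an estimated a number 39.1 percentage points lower from compound 1 to compound 4 (beyond the scatter).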

Compound 4, a percentage reported as inhibition, at one concentration (the size of the read-out at that concentration, not a potency): 91.4%
For compound 4 the middle estimate is 31.4 percentage points below the measured one; the range from low to high includes it.
By their numbers in this assay, from the lowest: compound 3; then compounds 4, 2 and 1 (each within the scatter of the next).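

In this assay, acetyl in place of hydrogen on the aromatic nitrogen, the change from 1H-pyrazol-3-yl to 1-acetyl-1H-pyrazol-3-yl, gives a number 7.7 percentage points lower from compound 1 to compound 4 (within the scatter). Among the compounds shown here, this is the first direct reading at this nitrogen, and it shows that the hydrogen there can give way to a group of 3 heavy atoms without a change beyond the scatter at this one concentration, so a larger group on this nitrogen does not by itself bring the number down. Nothing measured here explains this result.

As far as these compounds go, whether a longer acyl chain such as propanoyl, or a chain ending in an amine, would be accommodated on this same nitrogen remains open. The single concentration also leaves open whether compound 1 and compound 4 differ in potency.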